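Exchanging one aromatic group on compound 1

A few compounds are considered here, and "the series" means these few. Any claim that something is new, unique, unknown or untested is made for them only; others in the source may bear on it.

compound 1 `CS(=O)(=O)NC(=O)c1cc(C2CC2)c(OCC2CCN(Cc3ccc(OC(F)(F)F)cc3)CC2)cc1F`: 1.2
compound 2 `CS(=O)(=O)NC(=O)c1cc(C2CC2)c(OCC2CCN(C(c3ccccc3)c3ccccc3)CC2)cc1F`: 2.7

In a physicochemical assay for lipophilicity, read by LC-MS, using the shake flask method, at pH 7.4 (a lower number here means a more polar compound, a higher number a more lipophilic compound), compound 1 stands at the low end of the two numbers, with 1.2, while compound 2 lies higher, with 2.7, a gap beyond the usual scatter of repeated measurements. Compound 3 `CS(=O)(=O)NC(=O)c1cc(C2CC2)c(OCC2CCN(Cc3cc(Cl)cc(Cl)c3)CC2)cc1F` is still unmeasured. It keeps the core of compound 1 and changes one group: 3,5-dichlorophenyl in place of 4-(trifluoromethoxy)phenyl on a saturated chain carbon bound to an amine nitrogen in a ring. Among the measured compounds shown here, no pair of measured compounds shows this exchange, so the numbers offer no direct guide. A small upward step in this assay is expected, close to the edge of the scatter. The estimated change is a number 0.30 log units higher from compound 1 to compound 3 (within the scatter). For compound 3 the expected value is 1.5, with an estimated range from 1.1 to 2.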

Compound 3, distribution coefficient: 2
Beside the measured number, compound 3's estimate is 0.50 log units below it, and the stated range covers the measured number.
By their numbers in this assay, from the lowest: compound 1; then compound 3; then compound 2.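

On a saturated chain carbon bound to an amine nitrogen in a ring, 3,5-dichlorophenyl in place of 4-(trifluoromethoxy)phenyl gives, in this assay, a number 0.80 log units higher from compound 1 to compound 3 (beyond the scatter) with the rest of the molecule unchanged. Among the compounds shown here, this is the first measured step in which a single exchange at this place can be read on its own, and it shows that the reading responds to the substituents even though both groups contain one six-membered aromatic ring of carbon only. Nothing measured here accounts for the size of this step.

On these data alone, the two chlorines and the trifluoromethoxy group are exchanged together, so the share of each stays open. As far as these compounds go, it also remains open how this place would respond to a 4-chlorophenyl, a 4-cyanophenyl or an unsubstituted phenyl group.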